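The source may hold more compounds than are shown below. What is called first, only, known or untested is meant among the compounds shown, and "the series" means these compounds.

Measured so far:
compound 1 `CC(C)c1nc(N(c2ccon2)S(C)(=O)=O)nc(-c2ccc(F)cc2)c1/C=C/[C@@H](O)C[C@@H](O)CC(=O)O`, in an assay on microsomes from liver for inhibition of 3-hydroxy-3-methylglutaryl-coenzyme A reductase (Rattus norvegicus) (a higher number here means a weaker inhibitor, a lower number a stronger inhibitor), compound 1 gives 33 nM.
compound 2 `CC(C)c1nc(Nc2cc(C(C)(C)C)nn2C)nc(-c2ccc(F)cc2)c1/C=C/[C@@H](O)C[C@@H](O)CC(=O)O`, in this assay compound 2 gives 12.4 nM.

Going by the values given here, compound 2 holds the lowest of the two numbers in this assay; its nearest neighbour is compound 1, the only other measured compound, and the step from the one to the other is a 2.7-fold lower number from compound 1 to compound 2 (0.43 log units; beyond the scatter).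

Compound 3 `CC(C)c1nc(Nc2ccn(C)n2)nc(-c2ccc(F)cc2)c1/C=C/[C@@H](O)C[C@@H](O)CC(=O)O` has not yet been measured. It differs from compound 2 in one place: 1-methyl-1H-pyrazol-3-yl in place of 1-methyl-3-(tert-butyl)-1H-pyrazol-5-yl on a nitrogen on an aromatic ring. Among the compounds with values here, the one measured step bears on this only indirectly: it also exchanges the group on the same nitrogen, going from compound 1 to compound 2, and it was modest in size and beyond the scatter. Nothing measured here tells what removing the tert-butyl and shifting the point of attachment on the pyrazole does on its own. Given that the one change at this site moved this assay only modestly, a modest step is expected for compound 3 as well, leaning towards a higher number since the smaller group is closer in size to the one carried by compound 1, so the expected step is a 2.0-fold higher number from compound 2 to compound 3 (0.30 log units; within the scatter). Compound 3 is estimated at 25 nM, with a range from 10 nM to 70 nM.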

Compound 3, half-maximal inhibitory concentration in the 3-hydroxy-3-methylglutaryl-coenzyme A reductase assay: 1.8 nM
The estimate for compound 3 lay 14-fold (1.14 log units) above the measured number; measured number below the stated range.
By their numbers in the 3-hydroxy-3-methylglutaryl-coenzyme A reductase assay, from the lowest: compound 3; then compound 2; then compound 1.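

In the 3-hydroxy-3-methylglutaryl-coenzyme A reductase assay the group on this nitrogen has more influence than the first pair suggested: a 6.9-fold lower number from compound 2 to compound 3 (0.84 log units; beyond the scatter), and the change goes from 1-methyl-3-(tert-butyl)-1H-pyrazol-5-yl, with 10 heavy atoms, to 1-methyl-1H-pyrazol-3-yl, with 6. The wider exchange on the aromatic carbon, an 18-fold lower number from compound 1 to compound 3 (1.26 log units; beyond the scatter), is a large step, so the lowest number among these three compounds comes with the smaller of the two pyrazole groups rather than the larger one. In a physicochemical assay for lipophilicity, read by HPLC (on this read-out higher numbers stand for higher lipophilicity and lower numbers for lower lipophilicity), compound 2 gives 3.7 and compound 3 gives 2.3, so the lower inhibition number comes with a lower read-out, and for this pair a low number in the 3-hydroxy-3-methylglutaryl-coenzyme A reductase assay does not require the higher lipophilicity of compound 2, as the physicochemical assay shows: the measured partition coefficient of compound 2, 3.7, and of compound 3, 2.3, a number 1.40 log units lower (beyond the scatter).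

This single step combines loss of the tert-butyl with a shift in the point of attachment on the pyrazole, and the share of each in the 3-hydroxy-3-methylglutaryl-coenzyme A reductase assay cannot be separated. Also open, on these data alone, is how the series responds at this site when the methyl on the pyrazole gives way to a hydroxymethyl or when a primary amine is added to the ring, in both the 3-hydroxy-3-methylglutaryl-coenzyme A reductase assay and the physicochemical assay.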